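The source may hold more compounds than are shown below. What is called first, only, known or untested is meant among the compounds shown, and "the series" means these compounds.

Measured in a functional assay on MCF7 cells (Homo sapiens) for antiproliferative activity; a higher number here means a weaker inhibitor, a lower number a stronger inhibitor:
- compound 1 `N#CN/C(=N\CCCCCCCOc1ccccc1)Nc1cccnc1`: 42 nM
- compound 2 `N#CN/C(=N\CCCCCCOc1ccccc1Cl)Nc1ccncc1`: 1.9 nM
- compound 3 `COc1ccccc1OCCCCCC/N=C(\NC#N)Nc1ccncc1`: 1.1 nM

Compound 3, at 1.1 nM, sits at the low end of these numbers together with compound 2, at 1.9 nM, the two lying within the scatter of each other. Compound 1, at 42 nM, gives a much higher number, but it differs from compound 3 in more than one place and offers little guidance here.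

Compound 4 `COc1cccc(OCCCCCC/N=C(\NC#N)Nc2ccncc2)c1` has the same atoms as compound 3, joined differently: 3-methoxyphenyl in place of 2-methoxyphenyl on an oxygen on a saturated carbon. In words, 3-methoxyphenyl stands in place of 2-methoxyphenyl on an oxygen on a saturated carbon.

Going by the values given here, no measured step makes this kind of change. The nearest is a 1.7-fold lower number from compound 2 to compound 3 (0.24 log units; within the scatter), where methoxy replaced chloro on an aromatic carbon, and that step stayed within the scatter. With so little evidence, no change beyond the scatter is expected, though the range must stay wide. The expected step is a 1.4-fold higher number from compound 3 to compound 4 (0.13 log units; within the scatter). The estimated value for compound 4 is 1.5 nM, with an expected range from 0.4 nM to 7 nM.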

Compound 4, half-maximal inhibitory concentration: 3.8 nM
Estimate against measurement, compound 4: 2.5-fold (0.40 log units) below; the measured number falls inside the stated range.
By their numbers in this assay, from the lowest: compounds 3, 2 and 4 (each within the scatter of the next, the first and the last beyond it); then compound 1.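

In this assay, 3-methoxyphenyl in place of 2-methoxyphenyl on the oxygen gives a 3.5-fold higher number from compound 3 to compound 4 (0.54 log units; beyond the scatter) and shows that, with the same atoms, how the methoxy group is attached to the ring can shift the number modestly, something the earlier methoxy-for-chloro step could not reveal. Against the chloro compound, 3-methoxyphenyl in place of 2-chlorophenyl gives a 2.0-fold higher number from compound 2 to compound 4 (0.30 log units; within the scatter) and so does not separate the two compounds, which means only compound 3 stands apart from compound 4 here. Nothing available explains this shift.

On these data alone, whether an amine or a carboxylic acid on the ring in place of methoxy would keep numbers this low remains open. The effect of a longer chain also stays unsettled, as compound 1 differs from these compounds in more than one place.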